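Chloro for fluoro on the shared core

The source may report more compounds than this note shows. Statements on the series, on what has been measured and on what is new or still open speak of the compounds shown alone.

In a functional assay on BXPC-3 cells (Homo sapiens) for inhibition, read by MTT assay, with a stated time of 72 h (a higher number here means a weaker inhibitor, a lower number a stronger inhibitor), compound 1 `O=C(Nc1cccc2cccnc12)c1cccc(Br)n1` gives > 10000 nM, which is a limit of the assay and not a number. Compound 2 `Cc1cnc(C(=O)Nc2ccc(Br)c3cccnc23)cn1` likewise gives > 10000 nM in this assay, again a limit. Compound 3 `Cc1cnc(C(=O)Nc2cc(F)cc3cccnc23)cn1` gives > 10000 nM in this assay, also a limit. Among the compounds with values here, compound 3 thus stands at the same limit as the two other values shown; nothing separates the three, and no measured step between any pair of them exists. Compound 4 `Cc1cnc(C(=O)Nc2cc(Cl)cc3cccnc23)cn1` differs from compound 3 by chloro in place of fluoro on an aromatic carbon, the place being meta to a fused ring, meta to a large group and para to a fused ring. No measured step of this kind is shown, so the expected size of the step rests only on (the limit of > 10000 nM in this assay, at which 3 of the 3 values shown sit). Because the limit of > 10000 nM in this assay, at which 3 of the 3 values shown sit, holds all three values shown, the step from compound 3 to compound 4 is expected to be none beyond the scatter, at a step that the limit leaves unreadable from compound 3 to compound 4. Compound 4 is therefore estimated at 15000 nM in this assay, with a range of 5000 nM to 50000 nM, most probably reported again only as a limit.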

Compound 4, half-maximal inhibitory concentration: 5200 nM
Estimate against measurement, compound 4: 2.9-fold (0.46 log units) above, within the range that was stated.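

Compound 3 gives > 10000 nM in this assay, which is a limit of the assay and not a number. Compound 4 gives 5200 nM in this assay. Chloro in place of fluoro at this place, meta to a fused ring and para to a fused ring, yields an at least 1.9-fold lower number from compound 3 to compound 4 (0.28 log units; that floor lies within the scatter), a step with a floor but no upper end. Compound 4 is thus the only compound shown with a value that is a number, and the rest stay at one limit: the limit of > 10000 nM in this assay, at which 3 of the 4 values shown sit.

No other step among the compounds shown can be read. Going by these compounds, whether an amine or a methoxy group at this same place would give a lower number than chloro stays open, as does the true size of the step from fluoro to chloro.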